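Relocating a methyl group within the amine arm of compound 1

A few compounds are considered here, and "the series" means these few. Any claim that something is new, unique, unknown or untested is made for them only; others in the source may bear on it.

Compound 1 `C[C@@H](NCC1CCN(CCCc2c[nH]c3ccc(-n4cnnc4)cc23)CC1)c1ccccc1` gives 1.4 nM in an assay on CHO cells for displacement of a labelled ligand from 5-hydroxytryptamine receptor 1D (Homo sapiens) (a lower number here means a stronger inhibitor, a higher number a weaker inhibitor), the lowest of the three numbers recorded. Nearest to it is compound 2 `CN(C1CCN(CCCc2c[nH]c3ccc(-n4cnnc4)cc23)CC1)S(=O)(=O)c1ccccc1`, which gives 1.5 nM; furthest is compound 3 `OC[C@H](NC1CCN(CCCc2c[nH]c3ccc(Cn4cncn4)cc23)CC1)c1ccccc1`, which gives 23 nM. Within the data shown here, the only single-point step among the measured compounds is that between the first two: a 1.1-fold higher number from compound 1 to compound 2 (0.03 log units; within the scatter), so exchanging the amine substituent on the saturated ring carbon of the shared core, and with it the hydrogen-bond donor, left the number essentially unchanged. Compound 3 differs from compound 1 in several places at once, so its higher number cannot be traced to any one change.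

Compound 4 `CN(Cc1ccccc1)CC1CCN(CCCc2c[nH]c3ccc(-n4cnnc4)cc23)CC1` has the same atoms as compound 1, joined differently: benzyl(methyl)amino in place of (1-phenylethyl)amino on a saturated chain carbon bound to a saturated ring carbon. The methyl that sat on the chain carbon next to the phenyl ring now sits on the nitrogen, removing the hydrogen-bond donor and the stereocentre. Because a 1.1-fold higher number from compound 1 to compound 2 (0.03 log units; within the scatter) showed that this part of the molecule tolerates a larger change at the nitrogen without penalty, a step of a 1.8-fold higher number from compound 1 to compound 4 (0.25 log units; within the scatter) is expected, no larger than the scatter. Compound 4 is therefore estimated at 2.5 nM, within 0.8 nM to 8 nM.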

Compound 4, half-maximal inhibitory concentration: 0.9 nM
Estimate against measurement, compound 4: 2.8-fold (0.44 log units) above; low and high end bracket the measured number.
By their numbers in this assay, from the lowest: compounds 4, 1 and 2 (each within the scatter of the next); then compound 3.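

In this assay, exchanging (1-phenylethyl)amino for benzyl(methyl)amino on a saturated chain carbon bound to a saturated ring carbon gives a 1.6-fold lower number from compound 1 to compound 4 (0.19 log units; within the scatter), so an isomeric rearrangement that removes both the hydrogen-bond donor and the defined stereocentre leaves no change that can be told from the scatter. The step of a 1.7-fold lower number from compound 2 to compound 4 (0.22 log units; within the scatter) is also within the scatter, so the sulfonyl-bearing methyl(phenylsulfonyl)amino of compound 2 and the (benzyl(methyl)amino)methyl of compound 4 cannot be separated at this position, and the three compounds now form one group whichever of these arms they carry. No measurement here accounts for this tolerance.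

The compounds shown leave open whether the amine nitrogen of this arm is needed at all, which an ether oxygen in its place would test, and whether a phenethyl group or a longer chain on that nitrogen would still sit within the same range. They also leave open how much of the higher number of compound 3 belongs to its hydroxymethyl group and how much to its other differences from compound 1.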